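Methoxy to Cyano on the Phenyl of Compound 1

This account rests on a few compounds, and the source may have more. Where it says the series, first, only, none or still open, it means among the compounds named here.

Compound 1 `CCOC(=O)c1sc(NC(=O)Cn2cc(-c3ccc(OC)cc3)nn2)nc1C` gives 2330 nM in a functional assay on BMDM cells (Mus musculus, strain C57BL/6) for inhibition, with a stated time of 2 days; on this read-out higher numbers stand for weaker inhibition and lower numbers for stronger inhibition.
Compound 2 `COc1ccc(-c2cn(CC(=O)Nc3nc(C)cs3)nn2)cc1` gives 3890 nM in this assay.
Compound 3 `COc1cccc(-c2cn(-c3ccc(C(F)(F)F)cc3)nc2C(=O)NC2CCCCC2)c1` reaches only > 30000 nM in this assay, which is a limit of the assay and not a number.

Compound 1 stands lowest of the two numbers shown in this assay, with compound 2 nearest; the step of a 1.7-fold higher number from compound 1 to compound 2 (0.22 log units; within the scatter) is within the scatter. The limit of > 30000 nM in this assay, at which 1 of the 3 values shown sits, belongs to compound 3 alone. Compound 4 `CCOC(=O)c1sc(NC(=O)Cn2cc(-c3ccc(C#N)cc3)nn2)nc1C` differs from compound 1 by cyano in place of methoxy on an aromatic carbon. Among the compounds with values here, no measured step touches this position, so no step beyond the scatter is expected from it in this assay. Compound 4 is therefore estimated at 3000 nM, between 900 nM and 10000 nM. The expected step from compound 1 is a 1.3-fold higher number from compound 1 to compound 4 (0.11 log units; within the scatter).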

Compound 4, half-maximal inhibitory concentration: 310 nM
Estimate against measurement, compound 4: 9.7-fold (0.99 log units) above; measured number below the stated range.
By their numbers in this assay, from the lowest: compound 4; then compounds 1 and 2 (each within the scatter of the next). At a limit, above all of these: compound 3.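

Within the data shown here, with the 4-methoxyphenyl changed to 4-cyanophenyl, this assay shows a 7.5-fold lower number from compound 1 to compound 4 (0.88 log units; beyond the scatter), so this position, untouched by the earlier steps, does respond to the group placed on it. It is also the only step shown that lies beyond the scatter, as the earlier loss of the ethoxycarbonyl did not. The data shown offer no measured explanation for this step.

As far as these compounds go, whether an amine or a carboxylic acid at this place would give a similar number remains open. So does whether cyano would have the same effect on compound 2, which lacks the ethoxycarbonyl.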